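Furan-2-yl for phenyl: a two-compound baseline

The compounds below may be only part of what the source reports. "The series", "measured", "known", "first", "only" and "open" are said of these compounds alone.

Measured compounds:
Compound 1 `Nc1ccccc1-c1cc(-c2ccccc2)n[nH]1`: 9%
Compound 2 `COc1ccc(-c2cc(-c3ccccc3N)[nH]n2)cc1`: 2%

In an assay on CHO cells for displacement of a labelled ligand from adenosine receptor A1 (Homo sapiens), read by scintillation counting, tested at 1 uM (on this read-out higher numbers stand for more inhibition at the one concentration tested (going by the name of the read-out) and lower numbers for less inhibition), compound 1 gives 9%, the higher of the two numbers recorded, but the step of a number 7 percentage points lower from compound 1 to compound 2 (within the scatter) is within the scatter, so the two values cannot be told apart. Compound 2 gives 2%.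

Compound 3 `Nc1ccccc1-c1cc(-c2ccco2)n[nH]1` carries the same core as compound 1, with the difference (furan-2-yl in place of phenyl on an aromatic carbon). Among the measured compounds shown here, no measured step touches the ring that is exchanged here; the only step recorded concerns a methoxy on the other aromatic ring, and it stayed within the scatter. There is therefore no measured basis for a shift in either direction in this assay, and compound 3 is expected to land near compound 1, with the step of a number 1 percentage points lower from compound 1 to compound 3 (within the scatter) expected to stay within the scatter. Compound 3 is estimated at 8%, with a range from 0% to 25%.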

Compound 3, a percentage reported as inhibition, at one concentration (the size of the read-out at that concentration, not a potency): 4%
Compound 3: middle estimate off by 4 percentage points, on the high side; the measured number falls inside the stated range.
By their numbers in this assay, from the lowest: compounds 2, 3 and 1 (each within the scatter of the next).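

In this assay, furan-2-yl in place of phenyl on the aromatic carbon next to the ring nitrogen gives a number 5 percentage points lower from compound 1 to compound 3 (within the scatter), so with a five-membered aromatic ring with a hydrogen-bond acceptor here the number is level as far as this read-out can tell. With compound 3 at 4%, this series remains at the low end of the scale, where the change in ring size and hetero atom content leaves no readable difference and a further loss would be hard to detect. No available evidence bears on the origin of these low numbers.

Going by these compounds, whether a carboxylic acid or a morpholine on this aromatic carbon would give a number beyond the scatter remains open. Also open, on these data alone, is the outcome of an acetamide in place of the free amine on the shared core.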